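This account rests on a few compounds, and the source may have more. Where it says the series, first, only, none or still open, it means among the compounds named here.

In a functional assay on MDA-MB-231 cells (Homo sapiens) for cytotoxicity, read by MTT assay, with a stated time of 24 h (on this read-out higher numbers stand for weaker inhibition and lower numbers for stronger inhibition), three compounds have been measured so far. Compound 1 (`NCC(=O)NCc1nnc(-c2ccccc2)o1`) gives 283 nM, compound 2 (`C[C@@H](N)C(=O)NCc1nnc(-c2ccc(F)cc2)o1`) gives 247 nM, and compound 3 (`COc1ccc(-c2nnc(CNC(=O)[C@@H](C)N)o2)cc1`) gives 295 nM. Compound 2 therefore stands within the usual scatter of both other compounds, and these values do not separate it from either one.

Compound 4 (`C[C@@H](N)C(=O)NCc1nnc(-c2ccc([N+](=O)[O-])cc2)o1`) has yet to be measured in this assay. It differs from compound 2 in one place, with nitro in place of fluoro on an aromatic carbon.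

Within the data shown here, only one measured step bears directly on this change, the replacement of the same fluoro by methoxy: a 1.2-fold higher number from compound 2 to compound 3 (0.08 log units; within the scatter). That step is small and lies within the scatter. Among the measured compounds shown here, it is also the only exchange at this place, and no nitro compound has yet been measured, so it offers limited guidance. For the measured compounds named here, with only that small step from compound 3 to go on, and with compound 2 at 247 nM, the step to compound 4 is expected to stay within the scatter, and neither direction is favoured.

The expected change is slight: a 1.1-fold higher number from compound 2 to compound 4 (0.02 log units; within the scatter). For compound 4, the estimated value is 260 nM, with an expected range from 125 nM to 540 nM.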

Compound 4, half-maximal inhibitory concentration: 261 nM
Compound 4: middle estimate off by 1.0-fold (0.00 log units), on the low side, and the stated range covers the measured number.
By their numbers in this assay, from the lowest: compounds 2, 4, 1 and 3 (each within the scatter of the next).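

In this assay, the aromatic carbon para to a large group has now carried fluoro, methoxy and nitro, and these values do not separate the three groups. Nitro brings three heavy atoms and two hydrogen-bond acceptors in place of the single fluorine, yet the change reads as a 1.1-fold higher number from compound 2 to compound 4 (0.02 log units; within the scatter) and the exchange of methoxy for nitro as a 1.1-fold lower number from compound 3 to compound 4 (0.05 log units; within the scatter), so the earlier single exchange at this place, a 1.2-fold higher number from compound 2 to compound 3 (0.08 log units; within the scatter), no longer stands alone in lying within the scatter. Nothing available here explains why these three groups give such similar numbers.

Going by these compounds, whether an amine or a carboxylic acid on this aromatic carbon would also stay within the scatter remains open, and so does the outcome of a group that changes the count of heavy atoms far more, such as a longer chain. On these data alone, compound 1 differs from each of the other compounds in more than one place, so the effect of the methyl group on the chain that carries the free amine also remains open, as does that of any larger alkyl group there.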